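A methyl on the phenyl ring of compound 2

The source may hold more compounds than are shown below. What is called first, only, known or untested is meant among the compounds shown, and "the series" means these compounds.

Compound 1, `COC(=O)c1cc(-c2csc(N/N=C/c3ccc(Cl)cc3Cl)n2)ccc1OCc1ccccc1`, gives 66.3% in a functional assay, read by spectrophotometry, with a stated time of 15 min, tested at 60 ug/mL; a lower number here means a weaker effect, a higher number a stronger effect of the compound at the concentration tested.
Compound 2, `Clc1ccc(/C=N/Nc2nc(-c3ccccc3)cs2)c(Cl)c1`, gives 80.4% in this assay.
Compound 3, `COC(=O)c1cc(-c2csc(N/N=C/c3cccs3)n2)ccc1OCc1ccccc1`, gives 84.4% in this assay.

Compound 2 stands second highest of the three numbers: compound 3 lies within the scatter of it, while compound 1 sits beyond the scatter below it. Compound 4, `Cc1ccc(-c2csc(N/N=C/c3ccc(Cl)cc3Cl)n2)cc1`, differs from compound 2 by methyl in place of hydrogen on an aromatic carbon. Among the measured compounds shown here, none of the measured steps bears on this change. The only step shown, a number 18.1 percentage points higher from compound 1 to compound 3 (beyond the scatter), concerns the carbon with a double bond to nitrogen and not the six-membered aromatic ring of carbon only that is touched here. For the measured compounds named here, with no step to guide a shift in this assay, the expected change is none beyond the scatter: a number 2.4 percentage points lower from compound 2 to compound 4 (within the scatter). Compound 4 is therefore estimated at 78%, with a range from 64% to 90%.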

Compound 4, a percentage reported as inhibition, at one concentration (the size of the read-out at that concentration, not a potency): 83.2%
Estimate against measurement, compound 4: 5.2 percentage points below; the range from low to high includes it.
By their numbers in this assay, from the lowest: compound 1; then compounds 2, 4 and 3 (each within the scatter of the next).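

In this assay the change from phenyl to 4-methylphenyl gives (a number 2.8 percentage points higher from compound 2 to compound 4 (within the scatter)), so a methyl in place of hydrogen at this place, para to a large group, leaves the read-out within the scatter. This is the first step shown that touches this six-membered aromatic ring, and a single small group is all it tests. No measurement on hand accounts for the result. Open, as far as these compounds go, is whether an amine, a carboxylic acid or a longer chain here would also stay within the scatter. Also open, from the compounds shown here alone, is whether the methyl would do the same alongside thiophen-2-yl in place of 2,4-dichlorophenyl.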